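Replacing One Ring Group on the Leading Compound

The compounds below may be only part of what the source reports. "The series", "measured", "known", "first", "only" and "open" are said of these compounds alone.

Within the data shown here, in an ADME assay on the whole organism (Rattus norvegicus) for pharmacokinetics, at a dose of 2 mg/kg by the oral route (on this read-out higher numbers stand for higher oral bioavailability and lower numbers for lower oral bioavailability), compound 2 `CC(C)(NC(=O)c1cnc(-n2cccn2)nc1O)c1ccccc1` gives 99%, the higher of the two numbers so far. Compound 1 `O=C(NCc1ccc(F)cc1)c1cnc(-c2ccccn2)nc1O` gives 67%. The gap between these two compounds lies clearly beyond the scatter. Compound 3 `CC(C)(NC(=O)c1cnc(-c2cc(C(=O)O)ccn2)nc1O)c1ccccc1` carries 4-carboxypyridin-2-yl in place of 1H-pyrazol-1-yl on an aromatic carbon. Among the measured compounds shown here, no two measured compounds differ in only one place, so the data do not show what this change alone does, and any forecast is uncertain. The expected change is a fall beyond the scatter, a number 44 percentage points lower from compound 2 to compound 3 (beyond the scatter). For compound 3, the estimated value is 55%, with an expected range of 20% to 90%.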

Compound 3, oral bioavailability: 5%
The estimate for compound 3 lay 50 percentage points above the measured number; the whole stated range lies above it.
By their numbers in this assay, from the lowest: compound 3; then compound 1; then compound 2.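

Among these compounds, the swap of 1H-pyrazol-1-yl for 4-carboxypyridin-2-yl gives the first comparison that differs in one place, and in this assay it gives a number 94 percentage points lower from compound 2 to compound 3 (beyond the scatter) on this carbon between two ring nitrogen atoms. What sits at this position can therefore matter greatly for this read-out, at least for this pair of groups. Nothing measured here accounts for the fall.

The ring and the carboxylic acid enter together, so the compounds shown leave open which of them goes with the fall. A methyl ester in place of the acid, on the same pyridine ring, would help separate the two.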